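The source may report more compounds than this note shows. Statements on the series, on what has been measured and on what is new or still open speak of the compounds shown alone.

In a functional assay on HeLa cells (Homo sapiens) for inhibition, read by sulforhodamine B assay (a higher number here means a weaker inhibitor, a lower number a stronger inhibitor), compound 2 `CCCN(CCC)C1=CC(=O)c2nc3n(c2C1=O)[C@H]1OC[C@@H](O)[C@H]1OC3` gives > 16000 nM, which is a limit of the assay and not a number. That places it at the limit of > 16000 nM in this assay, at which 1 of the 2 values shown sits. Where compound 2 carries dipropylamino, compound 1 `CCc1ccc(NC2=CC(=O)c3nc4n(c3C2=O)[C@H]2OC[C@@H](O)[C@H]2OC4)cc1` carries (4-ethylphenyl)amino and gives 3990 nM, a true measured number.

The next structure is compound 3 `O=C1C=C(Nc2ccccc2)C(=O)c2c1nc1n2[C@H]2OC[C@@H](O)[C@H]2OC1`, with anilino in place of dipropylamino on a double-bonded ring carbon. The chain-bearing amino group thus gives way to one bearing an aromatic ring.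

Among the compounds with values here, only one measured step bears on this change, and it also swaps dipropylamino against a ring-bearing amino group: an at least 4.0-fold higher number from compound 1 to compound 2 (0.60 log units; beyond the scatter). Read backwards, that step points to a lower number for compound 3, meaning a stronger inhibitor. Because the size of an at least 4.0-fold higher number from compound 1 to compound 2 (0.60 log units; beyond the scatter) is only a lower bound, the gain could be larger, and the expectation rests on this single comparison.

The expected change is an at least 3.5-fold lower number from compound 2 to compound 3 (0.55 log units; beyond the scatter), beyond the scatter and towards stronger inhibition. For compound 3 the estimated value is 4500 nM, with an expected range of 1500 nM to 13000 nM.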

Compound 3, half-maximal inhibitory concentration: 5620 nM
Compound 3: middle estimate off by 1.2-fold (0.10 log units), on the low side; the measured number falls inside the stated range.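

In this assay, anilino on the double-bonded ring carbon gives an at least 2.8-fold lower number from compound 2 to compound 3 (0.45 log units; beyond the scatter), so the gap seen earlier between dipropylamino and (4-ethylphenyl)amino is no longer a single observation: a second amino group bearing an aromatic ring also lies on the stronger side of dipropylamino. Hydrogen in place of ethyl on the aromatic carbon gives a 1.4-fold higher number from compound 1 to compound 3 (0.15 log units; within the scatter), so the ethyl group makes no difference that can be told from the scatter in this pair, and the plain aromatic ring on the amino group is enough to reach this level of inhibition. Compound 2 stands at a limit and not a number, so only a lower bound on the size of the step away from it can be read: the limit of > 16000 nM in this assay, at which 1 of the 3 values shown sits.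

The change from dipropylamino to anilino brings in an aromatic ring and a hydrogen-bond donor together, and these compounds cannot show which of the two matters. Propylamino, which keeps a chain and adds the nitrogen hydrogen, and cyclohexylamino, which carries a ring that is not aromatic, would separate the two, while a methoxy group or a chlorine on the aromatic ring remains an open question as well.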